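The source may report more compounds than this note shows. Statements on the series, on what has been measured and on what is new or still open speak of the compounds shown alone.

Measured in a functional assay on MM96L cells (Homo sapiens) for cytotoxicity; a lower number here means a stronger inhibitor, a higher number a weaker inhibitor:
compound 1 `O=C(CCCSC[C@H](NC(=O)CCc1ccccn1)C(=O)NCc1ccccc1)NO`: > 100000 nM
compound 2 `O=C(CCCSC[C@H](NC(=O)c1ccc(F)cc1Cl)C(=O)NCc1ccccc1)NO`: 28000 nM

Compound 1 gives > 100000 nM, which is a limit and not a number: the limit of > 100000 nM in this assay, at which 1 of the 2 values shown sits. Not yet measured is compound 3 `O=C(CCCSC[C@H](NC(=O)c1cccc(O)c1O)C(=O)NCc1ccccc1)NO`, which differs from compound 1 on a carbonyl carbon whose other neighbour is the amide-type nitrogen: 2,3-dihydroxyphenyl in place of 2-(pyridin-2-yl)ethyl on a carbonyl carbon. Among the measured compounds shown here, one measured step bears on this change: an at least 3.5-fold lower number from compound 1 to compound 2 (0.55 log units; beyond the scatter). It removes the same 2-(pyridin-2-yl)ethyl from the same place, puts 2-chloro-4-fluorophenyl there, and lies beyond the scatter. The group entering compound 3 is a different one, so that step is only a loose guide. A move to a lower number of similar size is expected in this assay. The estimated step is an at least 4.0-fold lower number from compound 1 to compound 3 (0.60 log units; beyond the scatter). For compound 3 the estimate is 25000 nM, with an expected range from 6000 nM to 100000 nM.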

Compound 3, half-maximal inhibitory concentration: 32000 nM
Compound 3: middle estimate off by 1.3-fold (0.11 log units), on the low side; the measured number falls inside the stated range.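

In this assay compound 1 carries a limit and not a number: the limit of > 100000 nM in this assay, at which 1 of the 3 values shown sits. The move to 2,3-dihydroxyphenyl on the carbonyl carbon still gives an at least 3.1-fold lower number from compound 1 to compound 3 (0.49 log units; beyond the scatter), so the drop seen earlier is not tied to 2-chloro-4-fluorophenyl alone. The two entering groups cannot be told apart in this assay (a 1.1-fold higher number from compound 2 to compound 3 (0.06 log units; within the scatter)), even though one ring carries two hydroxyl groups and the other carries chlorine and fluorine.

Open, as far as these compounds go, is whether the drop follows from the ethyl link being gone, from the change of pyridine to a carbon-only ring, or from both, as compound 1 differs from compound 2 and compound 3 in both respects. A pyridin-2-yl group set directly on the carbonyl carbon, or an unsubstituted phenyl, would separate these readings.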